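The source may hold more compounds than are shown below. What is called first, only, known or untested is meant among the compounds shown, and "the series" means these compounds.

Compound 1 `CC(=O)O[C@@H]1OC(=O)[C@](O)(C(C)=O)[C@@H]1C` and compound 2 `CC(=O)O[C@@H]1OC(=O)[C@](OC(C)=O)(C(C)=O)[C@@H]1C` share one core. In a functional assay on B16 cells (Mus musculus) for cytotoxicity, read by MTT assay (on this read-out lower numbers stand for stronger inhibition and higher numbers for weaker inhibition), compound 1 gives only a limit of the assay, > 50000 nM. In this assay compound 2 likewise gives only a limit, > 50000 nM. The step that the two limits leave unreadable from compound 1 to compound 2 is therefore unreadable, since both values sit at the limit of > 50000 nM in this assay, at which 2 of the 2 values shown sit. Compound 3 `CC(=O)O[C@@H]1OC(=O)[C@](Br)(C(C)=O)[C@@H]1C` carries a bromo in place of the acetoxy of compound 2 (bromo in place of acetoxy on a saturated ring carbon). Within the data shown here, no measured step shows how such a change acts. For compound 3 the estimated value is 80000 nM, with a range from 20000 nM to 300000 nM. The expected step that the limit leaves unreadable from compound 2 to compound 3 is thus small, most likely ending again at a limit.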

Compound 3, half-maximal inhibitory concentration: 9000 nM
Compound 3: middle estimate off by 8.9-fold (0.95 log units), on the high side, outside the stated range (below it).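

In this assay this saturated ring carbon proves sensitive to what it carries: bromo in place of acetoxy gives an at least 5.5-fold lower number from compound 2 to compound 3 (0.74 log units; beyond the scatter). Bromo in place of hydroxy gives an at least 5.5-fold lower number from compound 1 to compound 3 (0.74 log units; beyond the scatter), so the change shows up from either starting group. Among these compounds, compound 3 is the only one of the three with a measured number rather than a limit, so the bromo is the first group here to give a readable effect at this position. On these data alone, the true size of both steps stays open, since each starts from a limit: the limit of > 50000 nM in this assay, at which 2 of the 3 values shown sit. As far as these compounds go, whether a chloro or an amine on the same carbon would also lower the number also remains open.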